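Amide Chain Variation and Cytotoxicity in CEM-SS Cells

The source may hold more compounds than are shown below. What is called first, only, known or untested is meant among the compounds shown, and "the series" means these compounds.

Measured so far:
compound 1, `CCCC(=O)OCSc1ccccc1C(=O)NCCCCCC(N)=O`: 16.3 uM
compound 2, `CCCC(=O)OCSc1ccccc1C(=O)Nc1ccccc1C(N)=O`: 50.1 uM

Of the compounds shown here, two sharing the same core have been tested in an ADME assay on CEM-SS cells (Homo sapiens) for cytotoxicity, read by XTT assay, with a stated time of 6 days; a lower number here means that less compound is tolerated, a higher number that more compound is tolerated. Compound 1 gives 16.3 uM, and compound 2 gives 50.1 uM; compound 1 stands lowest of the two numbers, and the gap to compound 2 lies beyond the usual scatter. Compound 3, `CCCC(=O)OCSc1ccccc1C(=O)NCC(=O)NCC(N)=O`, has not yet been measured in this assay. It differs from compound 1 in one place: (carbamoylmethyl)carbamoyl in place of 4-carbamoylbutyl on a saturated chain carbon bound to an amide-type nitrogen. Among the compounds with values here, no step between two measured compounds has been recorded for a change of this kind, so direction and size must be expected rather than read off. Because compound 2 gives 50.1 uM, a higher number than compound 1, a modest rise is expected for compound 3, possibly within the scatter. The expected step of a 1.8-fold higher number from compound 1 to compound 3 (0.26 log units; within the scatter) is small and upward. Compound 3 is therefore estimated at 30 uM, within 12 uM to 80 uM.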

Compound 3, half-maximal toxic concentration: > 100 uM
Compound 3: a limit, no number; the forecaster's own chance of this, stated with the estimate: 20%; middle value at least 3.3-fold (0.52 log units) away from the limit.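

On a saturated chain carbon bound to an amide-type nitrogen, replacing 4-carbamoylbutyl with (carbamoylmethyl)carbamoyl brings an at least 6.1-fold higher number from compound 1 to compound 3 (0.78 log units; beyond the scatter) in this assay, the first step read at this position. Compound 3 carries a limit, not a number, and how far past it the compound lies cannot be told: the limit of > 100 uM in this assay, at which 1 of the 3 values shown sits. The group that enters holds more hydrogen-bond donors, hydrogen-bond acceptors, nitrogen and oxygen than the group that leaves, and this single step cannot show which of these differences matters.

From the compounds shown here alone, it remains open whether the inner carbonyl and nitrogen alone would give such a step, or whether the terminal carbamoyl is also needed. A chain ending in a carboxylic acid or an amine, or a longer chain keeping the same inner amide, would help separate these possibilities.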